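A few compounds are considered here, and "the series" means these few. Any claim that something is new, unique, unknown or untested is made for them only; others in the source may bear on it.

Measured so far in a functional assay on the whole organism for inhibition, with Mus musculus as the target, at a dose of 25 mg/kg by the oral route; a lower number here means less inhibition, a higher number more inhibition at the dose given (going by the name of the read-out):
compound 1 `Fc1cccc(N2CCN(CCCOc3ccc4c(c3)CCC4)CC2)c1` gives 19%;
compound 2 `Clc1ccc(N2CCN(CCCOc3ccc4c(c3)CCC4)CC2)cc1` gives 43%;
compound 3 `Clc1cc(Cl)cc(N2CCN(CCCCOc3ccc4c(c3)CCC4)CC2)c1` gives 0%.

Compound 2 stands highest of the three numbers, beyond the scatter from both of the others. Going by the values given here, the single one-point step measured is a number 24 percentage points higher from compound 1 to compound 2 (beyond the scatter). Compound 4 `CC(=O)c1ccc(N2CCN(CCCOc3ccc4c(c3)CCC4)CC2)cc1` differs from compound 2 by acetyl in place of chloro on an aromatic carbon. Among the compounds with values here, no measured step replaces chloro with acetyl; the only step on that ring swaps one halogen for another, so it bears on this change only loosely, showing that the substituent on that ring does move the read-out. With nothing to fix a direction, the expected step in this assay is a number 5 percentage points lower from compound 2 to compound 4 (within the scatter), none beyond the scatter. The estimate for compound 4 is 38%, between 10% and 62%.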

Compound 4, a percentage reported as inhibition, in the whole organism at one dose (the size of the read-out at that dose, not a potency): 13%
Beside the measured number, compound 4's estimate is 25 percentage points above it, and the stated range covers the measured number.
By their numbers in this assay, from the lowest: compound 3; then compounds 4 and 1 (each within the scatter of the next); then compound 2.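

In this assay acetyl in place of chloro on an aromatic carbon, para to a large group, gives a number 30 percentage points lower from compound 2 to compound 4 (beyond the scatter) and so the read-out turns on which group sits there, not merely on a group being present. The 4-acetylphenyl and 3-fluorophenyl groups are not separated in this assay, where the step is a number 6 percentage points lower from compound 1 to compound 4 (within the scatter) and stays within the scatter. Nothing measured here accounts for either step.

Open, as far as these compounds go, is whether compound 2's number is particular to chloro. A nitrile, a methoxy group or a bromo group at that same carbon would test this.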